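The source may report more compounds than this note shows. Statements on the series, on what has been measured and on what is new or still open speak of the compounds shown alone.

Measured so far:
compound 1, `CC(C(=O)NCc1ccc(C(F)(F)F)cc1N1CCC(Cc2ccccc2)CC1)c1ccc(NS(C)(=O)=O)c(F)c1`, 1.4 nM;
compound 2, `CCCOc1cc(C(F)(F)F)ccc1CNC(=O)C(C)c1ccc(NS(C)(=O)=O)c(F)c1`, 2 nM;
compound 3, `CCCCCCOc1cc(C(C)(F)F)ccc1CNC(=O)C(C)c1ccc(NS(C)(=O)=O)c(F)c1`, 0.8 nM.

All three were run in an assay on CHO cells for antagonist activity at transient receptor potential cation channel subfamily V member 1 (Homo sapiens), read by FLIPR; a higher number here means a weaker inhibitor, a lower number a stronger inhibitor. Compound 2 holds the highest of the three numbers; compound 1 sits within the scatter of it, while compound 3 lies below it by more than the scatter. Compound 4, `CC(C(=O)NCc1ccc(C(F)(F)F)cc1SCc1ccccc1)c1ccc(NS(C)(=O)=O)c(F)c1`, is not yet measured in this assay. It differs from compound 2 in one place: benzylsulfanyl in place of propoxy on an aromatic carbon. Compound 1 carries a large group at the same place and gives 1.4 nM, close to compound 2. On that basis the step from compound 2 to compound 4 is expected to be small, at most a modest move to a lower number, and may well stay within the scatter: a 1.5-fold lower number from compound 2 to compound 4 (0.19 log units; within the scatter). Compound 4 is therefore estimated at 1.3 nM, with a range from 0.4 nM to 4 nM.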

Compound 4, inhibition constant: 0.5 nM
Beside the measured number, compound 4's estimate is 2.6-fold (0.41 log units) above it; low and high end bracket the measured number.
By their numbers in this assay, from the lowest: compounds 4, 3, 1 and 2 (each within the scatter of the next, the first and the last beyond it).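

In this assay, among these compounds, benzylsulfanyl in place of propoxy gives a 4.0-fold lower number from compound 2 to compound 4 (0.60 log units; beyond the scatter), the only single-place step available. This aromatic carbon, meta to a trifluoromethyl group, therefore accepts a larger substituent carrying a six-membered aromatic ring with no loss in this read-out, and the number moves beyond the scatter. No supporting measurement accounts for the step.

The step exchanges oxygen for sulfur and adds the ring together, leaving the two changes unresolved. Benzyloxy or propylsulfanyl at this carbon would separate them.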